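The source may report more compounds than this note shows. Statements on the series, on what has been measured and on what is new or still open speak of the compounds shown alone.

Measured so far:
Compound 1 `CC(=O)N1N=C(c2ccc3ccccc3c2)OC1c1ccc(Br)cc1`: 2.08 ug/mL
Compound 2 `CC(=O)N1N=C(c2ccc3ccccc3c2)OC1c1ccc(F)cc1`: 1.82 ug/mL

In a functional assay on HepG2 cells (Homo sapiens) for antiproliferative activity, read by MTT assay, with a stated time of 48 h (a higher number here means a weaker inhibitor, a lower number a stronger inhibitor), compound 2 gives 1.82 ug/mL and sits within the scatter of compound 1, which gives 2.08 ug/mL. The two compounds therefore cannot be ranked. Compound 3 `CC(=O)N1N=C(c2ccc3ccccc3c2)OC1c1ccccc1[N+](=O)[O-]` keeps the shared core and its acetyl group but carries 2-nitrophenyl in place of 4-fluorophenyl on a saturated ring carbon.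

Going by the values given here, only one measured step bears on this change: a 1.1-fold lower number from compound 1 to compound 2 (0.06 log units; within the scatter), where fluoro replaces bromo on an aromatic carbon. That step is small and shows that this exchange on the aromatic ring left the number within the scatter. Among the compounds with values here, it is only a weak guide, since no measured compound carries 2-nitrophenyl and the new change is larger than that exchange. No step beyond the scatter is therefore expected, and no firm direction can be given, although the estimated step is a 1.2-fold higher number from compound 2 to compound 3 (0.08 log units; within the scatter). The range is kept wide to allow for a surprise. For compound 3 the expected value is 2.2 ug/mL, with an estimated range from 0.8 ug/mL to 6 ug/mL.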

Compound 3, half-maximal inhibitory concentration: 12.3 ug/mL
Compound 3: middle estimate off by 5.6-fold (0.75 log units), on the low side; measured number above the stated range.
By their numbers in this assay, from the lowest: compounds 2 and 1 (each within the scatter of the next); then compound 3.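

In this assay, the saturated ring carbon that carries the aromatic group turns out to be sensitive to what sits on that ring: 2-nitrophenyl in place of 4-fluorophenyl gives a 6.8-fold higher number from compound 2 to compound 3 (0.83 log units; beyond the scatter), and 2-nitrophenyl in place of 4-bromophenyl gives a 5.9-fold higher number from compound 1 to compound 3 (0.77 log units; beyond the scatter). Going by these compounds alone, the exchange of bromo for fluoro had left the number within the scatter, so only this new change shows that the group at this position can shift the result, here towards a weaker inhibitor, with compound 3 standing apart from both halogen compounds by a modest step. Nothing measured here explains the loss.

The change alters two things at once, the kind of group on the phenyl ring and where it sits on that ring, and the compounds shown cannot separate the two. From the compounds shown here alone, compounds carrying 4-nitrophenyl or 2-fluorophenyl at this carbon would tell them apart, and how a phenyl ring bearing an amine or a carboxylic acid would behave here also stays open.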